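Swapping the Sulfonyl Aryl Group and Cytotoxicity

The source may hold more compounds than are shown below. What is called first, only, known or untested is meant among the compounds shown, and "the series" means these compounds.

compound 1, `O=S(=O)(Nc1ccc(-c2nc3ccccc3o2)cc1)c1cccc(O)c1`: > 100000 nM
compound 2, `CCc1ccc(S(=O)(=O)Nc2ccc3oc(-c4ccccc4)nc3c2)cc1`: 81000 nM
compound 3, `O=S(=O)(Nc1ccc2oc(-c3ccccc3)nc2c1)c1ccc(Cl)c(Cl)c1`: 71000 nM

In an ADME assay on HEK293 cells (Homo sapiens) for cytotoxicity, read by resazurin assay, with a stated time of 48 h (a lower number here means that less compound is tolerated, a higher number that more compound is tolerated), compound 1 stands at a limit of the assay, > 100000 nM, rather than at a measured number (the limit of > 100000 nM in this assay, at which 1 of the 3 values shown sits). For the measured compounds named here, compound 2 gives 81000 nM and compound 3 gives 71000 nM, and the one measured step, a 1.1-fold lower number from compound 2 to compound 3 (0.06 log units; within the scatter), lies within the scatter. Compound 4, `COc1ccc(Cl)cc1S(=O)(=O)Nc1ccc(-c2nc3ccccc3o2)cc1`, carries 5-chloro-2-methoxyphenyl in place of 3-hydroxyphenyl on a sulfonyl sulfur. Going by the values given here, that measured step is the only one bearing on this change, since it too exchanges the aryl group on the sulfonyl sulfur, and it barely moved the number; so the step from compound 1 to compound 4 in this assay is expected to stay within the scatter, most likely again at the limit. Compound 4 is therefore estimated at 100000 nM, with a range of 40000 nM to 250000 nM, an expected step of a number no higher from compound 1 to compound 4 (the limit leaves the size open).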

Compound 4, half-maximal cytotoxic concentration: 75000 nM
The estimate for compound 4 lay 1.3-fold (0.12 log units) above the measured number; the measured number falls inside the stated range.
By their numbers in this assay, from the lowest: compounds 3, 4 and 2 (each within the scatter of the next). At a limit, above all of these: compound 1.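

In this assay, the exchange on the sulfonyl sulfur gives an at least 1.3-fold lower number from compound 1 to compound 4 (0.12 log units; that floor lies within the scatter). With compound 4, the core of compound 1 now carries a measured number, and 5-chloro-2-methoxyphenyl is tolerated there without a step shown to lie beyond the scatter. Compound 1 itself stays at a limit, so the true size of the step remains unknown: the limit of > 100000 nM in this assay, at which 1 of the 4 values shown sits.

Which part of the exchange matters, the lost hydroxy group, the chlorine or the methoxy group, remains open. So does whether an amine or a carboxylic acid on that aryl ring would shift the number in this assay.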